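The source may report more compounds than this note shows. Statements on the series, on what has been measured and on what is new or still open speak of the compounds shown alone.

For the measured compounds named here, compound 2, with the structure `COc1ccc(/C=C/C(=O)c2cccc(-c3cccc(F)c3)c2)cc1O`, stands at the higher end of the two numbers measured so far. In an assay on A549 cells for inhibition of transcription factor p65 (Homo sapiens), read by fluorescence, with a stated time of 2 h (a lower number here means a stronger inhibitor, a higher number a weaker inhibitor), compound 2 gives 9590 nM. Going by the values given here, the only other measured compound, compound 1 with the structure `COc1ccc(/C=C/C(=O)c2ccc(NC(C)=O)c(-c3ccc(F)cc3)c2)cc1OC`, gives 2650 nM in this assay, a gap beyond the usual scatter; the two compounds differ in several places, so no single step between them can be drawn.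

Compound 3, with the structure `COc1ccc(/C=C/C(=O)c2cccc(-c3cccc(F)c3)c2)cc1`, has not yet been measured. It differs from compound 2 in one place: hydrogen in place of hydroxy on an aromatic carbon. Among the compounds with values here, no pair of measured compounds shows this kind of change, so nothing in the data sets its size or direction. The step from compound 2 to compound 3 is therefore expected to be small, a 1.1-fold lower number from compound 2 to compound 3 (0.03 log units; within the scatter), and not clearly beyond the scatter in either direction. For compound 3 in this assay the estimated value is 9000 nM, within a range from 3000 nM to 27000 nM.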

Compound 3, half-maximal inhibitory concentration: > 50000 nM
Compound 3: only a limit was reported (the forecaster's own chance of this, stated with the estimate: 10%); middle value at least 5.5-fold (0.74 log units) away from the limit.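

Hydrogen in place of hydroxy, on an aromatic carbon ortho to a methoxy group, brings an at least 5.2-fold higher number from compound 2 to compound 3 (0.71 log units; beyond the scatter), so the earlier compounds gave no sign that this single hydroxy matters, and this pair shows that it does. In this assay compound 3 gives > 50000 nM, which is a limit of the assay and not a number. The step therefore has a known direction and a minimum size, but its full size stays unknown: the limit of > 50000 nM in this assay, at which 1 of the 3 values shown sits.

Hydroxy and hydrogen are the only two groups seen at this carbon with the rest of the structure unchanged, so this one pair cannot say whether the hydroxy is special or whether other groups would serve as well. An amine or a carboxylic acid at this carbon would help to answer that question.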